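Series notes: ring-substituted benzylamides, replacing cyclohexylsulfanyl with 3-fluorophenyl

The source may report more compounds than this note shows. Statements on the series, on what has been measured and on what is new or still open speak of the compounds shown alone.

Measured so far:
- compound 1 `CCCCN(C)c1cc(C(F)(F)F)ccc1CNC(=O)C(C)c1ccc(NS(C)(=O)=O)c(F)c1`: 1.2 nM
- compound 2 `CCCCCCSc1cc(C(F)(F)F)ccc1CNC(=O)C(C)c1ccc(NS(C)(=O)=O)c(F)c1`: 1.8 nM
- compound 3 `CC(C(=O)NCc1ccc(C(F)(F)F)cc1SC1CCCCC1)c1ccc(NS(C)(=O)=O)c(F)c1`: 0.5 nM

All three share one core and differ only in the group on an aromatic carbon. In an assay on CHO cells for antagonist activity at transient receptor potential cation channel subfamily V member 1 (Homo sapiens), read by FLIPR (on this read-out lower numbers stand for stronger inhibition and higher numbers for weaker inhibition), compound 3 gives the lowest of the three numbers; the nearest is compound 1 a 2.4-fold lower number from compound 1 to compound 3 (0.38 log units; beyond the scatter) and the furthest compound 2 a 3.6-fold lower number from compound 2 to compound 3 (0.56 log units; beyond the scatter), while the pair of compounds 1 and 2 a 1.5-fold higher number from compound 1 to compound 2 (0.18 log units; within the scatter) does not separate.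

Compound 4 `CC(C(=O)NCc1ccc(C(F)(F)F)cc1-c1cccc(F)c1)c1ccc(NS(C)(=O)=O)c(F)c1` carries the change (3-fluorophenyl in place of cyclohexylsulfanyl on an aromatic carbon). Within the data shown here, no measured step swaps a non-aromatic ring for an aromatic one, nor removes the sulfur; the two steps that bear on the position show that replacing a chain by a cyclohexyl on the sulfur lowers the number, and that the spread across the whole set is modest. A step back toward the level of compound 1 is therefore expected, of size a 3.0-fold higher number from compound 3 to compound 4 (0.48 log units; beyond the scatter), possibly still within the scatter. Compound 4 is estimated at 1.5 nM, range 0.5 nM to 5 nM.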

Compound 4, inhibition constant: 1.9 nM
Estimate against measurement, compound 4: 1.3-fold (0.10 log units) below, within the range that was stated.
By their numbers in this assay, from the lowest: compound 3; then compounds 1, 2 and 4 (each within the scatter of the next).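

In this assay, a group with an aromatic ring and no sulfur is accepted at this position: 3-fluorophenyl does not separate from hexylsulfanyl, with a 1.1-fold higher number from compound 2 to compound 4 (0.02 log units; within the scatter), or from butyl(methyl)amino, with a 1.6-fold higher number from compound 1 to compound 4 (0.20 log units; within the scatter). Cyclohexylsulfanyl alone stands apart, with a 3.8-fold higher number from compound 3 to compound 4 (0.58 log units; beyond the scatter), so the edge of compound 3 does not carry over to this aromatic ring. Nothing at hand explains that edge.

The compounds shown leave open whether the sulfur or the non-aromatic ring accounts for the edge of compound 3; cyclohexyl without the sulfur and phenylsulfanyl would separate the two. Also open, on these data alone, is what the fluorine contributes to compound 4, a question for plain phenyl.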